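Chloro in Place of Nitro: An Expected Standstill

The source may hold more compounds than are shown below. What is called first, only, known or untested is meant among the compounds shown, and "the series" means these compounds.

Of the compounds shown here, three have been tested in a functional assay on the whole organism (strain Swiss albino) with Mus musculus as the target, with a stated time of 0.5 h; a higher number here means that more compound is needed for the effect, a lower number that less compound is needed. Compound 1 `C/C(=N\Cc1cccnc1)c1cccc(N)c1` gives 30 mg/kg. Compound 2 `O=[N+]([O-])c1ccc(/C=N/Cc2cccnc2)cc1` gives 30 mg/kg. Compound 3 `COc1cc(/C=N/Cc2cccnc2)ccc1O` gives 30 mg/kg. At the digits reported compound 2 stands level with both compound 1 and compound 3; neither gap reaches beyond the usual scatter, so nothing separates the three on these numbers, and none of them can be called the more or the less potent.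

Compound 4 `Clc1ccc(/C=N/Cc2cccnc2)cc1` has not yet been measured in this assay. It differs from compound 2 in one place: chloro in place of nitro on an aromatic carbon.

Within the data shown here, no pair of measured compounds differs in one place only, so no measured step shows what such a change does here. The three values that exist all sit together, and the move from the nitro of compound 2 to chloro gives no ground for expecting a shift beyond the scatter. The step of no change at the digits printed from compound 2 to compound 4 (within the scatter) is therefore expected to stay within the scatter. Compound 4 is estimated at 30 mg/kg in this assay, with a range from 10 mg/kg to 100 mg/kg.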

Compound 4, minimum effective dose: 100 mg/kg
Estimate against measurement, compound 4: 3.3-fold (0.52 log units) below; low and high end bracket the measured number.
By their numbers in this assay, from the lowest: compounds 1, 2 and 3 (each within the scatter of the next); then compound 4.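

In this assay, chloro in place of nitro on this aromatic carbon gives a 3.3-fold higher number from compound 2 to compound 4 (0.52 log units; beyond the scatter), so the group held at this position, para to a group of 9 heavy atoms, can move the dose needed beyond the scatter. Among these compounds, the three earlier compounds, level at their shared value and with no pair differing in one place, could not show this, and the step itself remains modest. No measurement is at hand that bears on why the number rises with this exchange.

From the compounds shown here alone, it remains open whether a fluoro, a nitrile or a carboxylic acid at the same carbon would stay level with nitro or follow chloro. Going by these compounds, it also remains open whether chloro at another carbon of this ring would give a step of the same size.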